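Adding a Fluoro Group to Compound 1: What to Expect

The source may hold more compounds than are shown below. What is called first, only, known or untested is meant among the compounds shown, and "the series" means these compounds.

In an ADME assay on HOS cells (Homo sapiens) for cytotoxicity (on this read-out lower numbers stand for stronger inhibition and higher numbers for weaker inhibition), compound 1 (`O=C1c2ccc(O)c(O)c2C(=O)N1Cc1ccc(F)cc1`) is recorded as "not determined" (no result reported) and so has no number to stand on. The nearest measured relative is compound 2 (`O=C1c2ccc(O)c(O)c2C(=O)N1Cc1cccc(I)c1`), which shares the core of compound 1. In this assay, for the measured compounds named here, compound 2 gives 12000 nM as the only number available. Compound 3 (`O=C1c2ccc(O)c(O)c2C(=O)N1Cc1ccc(F)c(F)c1`) comes from compound 1 through one small change (fluoro in place of hydrogen on an aromatic carbon), with fluoro in place of hydrogen on an aromatic carbon. Going by the values given here, no measured pair shows what this change does in this assay and the data lack any direct guide. No step beyond the usual scatter is expected, and no direction is favoured. The estimate therefore leans on compound 2 at 12000 nM as its only anchor. For compound 3 the expected value is 15000 nM with an estimated range from 5000 nM to 50000 nM in this assay.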

Compound 3, half-maximal inhibitory concentration: 7940 nM
Estimate against measurement, compound 3: 1.9-fold (0.28 log units) above, and the stated range covers the measured number.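

In this assay compound 1 stands as "not determined" (no result reported) and so offers no number to set against compound 3, which means no new step can be read. On these data alone, what replacing hydrogen with fluoro does to this read-out stays open. Nothing shown here bears on the value of compound 3.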